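Shifting the methoxyphenyl group from compound 2 to compound 4

The source may report more compounds than this note shows. Statements on the series, on what has been measured and on what is new or still open speak of the compounds shown alone.

Compound 1 `COc1ccc(C2=NN(c3ccccc3Cl)C(c3cccc(Cl)c3)C2)cc1`: in a functional assay on NCI-H1299 cells (Homo sapiens) for cytotoxicity, read by a luciferase reporter and CellTiter-Glo, with a stated time of 72 h (on this read-out higher numbers stand for weaker inhibition and lower numbers for stronger inhibition), compound 1 gives 7200 nM.
Compound 2 `COc1ccc(C2=NN(c3cccc(Cl)c3)C(c3cccc(Cl)c3)C2)cc1`: in this assay compound 2 gives "not determined" (no result reported), that is, no result.
Compound 3 `COc1ccc(C2=NN(c3ccc(Cl)cc3)C(c3cccc(Cl)c3)C2)cc1`: in this assay compound 3 gives "not determined" (no result reported), that is, no result.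

Compound 2 stands without a number in this assay, and compound 3 is the further entry without one, so the only measured point in this set is compound 1. Compound 4 `COc1ccccc1C1=NN(c2cccc(Cl)c2)C(c2cccc(Cl)c2)C1` is built from compound 2 by a change of arrangement: 2-methoxyphenyl in place of 4-methoxyphenyl on a carbon with a double bond to nitrogen. Among the compounds with values here, with no measured step of this kind to lean on, the size and direction of the step from compound 2 to compound 4 in this assay cannot be anchored; a step within the usual scatter is as plausible as one beyond it. Resting on compound 1, compound 4 is expected to give about 8000 nM in this assay, with a range from 2000 nM to 30000 nM.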

Compound 4, half-maximal inhibitory concentration: 11700 nM
For compound 4 the middle estimate is 1.5-fold (0.17 log units) below the measured one; low and high end bracket the measured number.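

Within the data shown here, compound 2 has no number in this assay, so no step to compound 4 can be read. The compounds shown leave open whether 2-methoxyphenyl in place of 4-methoxyphenyl changes activity at all. No supporting evidence bears on this result.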